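The source may hold more compounds than are shown below. What is called first, only, known or untested is meant among the compounds shown, and "the series" means these compounds.

Compound 3, with the structure `COc1ccc(Oc2ccc([C@H]3S[C@@H](C)C(=O)Nc4c3c(C)nn4-c3ccccc3C)cc2)cc1`, is one of three close analogues that share one core and differ only in the group carried on the outer aromatic ring. Compound 1 is `COc1cccc(-c2ccc([C@H]3S[C@@H](C)C(=O)Nc4c3c(C)nn4-c3ccccc3C)cc2)c1` and compound 2 is `COc1ccccc1-c1ccc([C@H]2S[C@@H](C)C(=O)Nc3c2c(C)nn3-c2ccccc2C)cc1`. In an assay on isolated protein for agonist activity at Bile acid receptor (Homo sapiens), read by AlphaScreen, with a stated time of 30 min (on this read-out higher numbers stand for an effect only at larger amounts of compound and lower numbers for an effect already at smaller amounts), compound 1 gives 1800 nM, compound 2 gives 1100 nM, and compound 3 gives 2200 nM. Compound 3 sits at one edge of this small set, yet its distance from the others is slight: there is a 1.2-fold higher number from compound 1 to compound 3 (0.09 log units; within the scatter) and a 2.0-fold higher number from compound 2 to compound 3 (0.30 log units; within the scatter), and between the other two there is a 1.6-fold lower number from compound 1 to compound 2 (0.21 log units; within the scatter).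

Compound 4, `Cc1ccccc1-n1nc(C)c2c1NC(=O)[C@H](C)S[C@@H]2c1ccc(/C=C/c2ccccc2)cc1`, has not yet been measured. It departs from compound 3 by a single change, (2-phenylethenyl in place of 4-methoxyphenoxy on an aromatic carbon). Among the measured compounds shown here, none of the measured steps involves a 2-phenylethenyl group; every one of them exchanged one methoxy-bearing aryl or aryloxy group for another, and every one stayed within the scatter. For the measured compounds named here, on that basis no step in this assay beyond the scatter can be predicted in either direction, though the change is of a different kind from any already tested, so the uncertainty is wide. Compound 4 is therefore expected to give 2000 nM, with a plausible range from 500 nM to 8000 nM, which corresponds to an expected step of a 1.1-fold lower number from compound 3 to compound 4 (0.04 log units; within the scatter).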

Compound 4, half-maximal effective concentration: "not active" (no number reported)
Compound 4: no number reported, so the estimate cannot be set against anything.
By their numbers in this assay, from the lowest: compounds 2, 1 and 3 (each within the scatter of the next).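

In this assay, among the compounds shown here, compound 4 is reported as "not active" without a number, so no step from compound 3 to compound 4 can be read. The compounds shown leave open how far 2-phenylethenyl in place of 4-methoxyphenoxy shifts the response. No measurement shown here offers an explanation for this result.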